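A few compounds are considered here, and "the series" means these few. Any claim that something is new, unique, unknown or untested is made for them only; others in the source may bear on it.

Compound 1 `COc1cc(-c2nn(-c3cccc(NC(=O)c4cccc(C(F)(F)F)c4)c3)cc2-c2ccncc2)ccc1Cl` joins the shared core through an amide to a 3-(trifluoromethyl)phenyl ring. In a functional assay on HOP-62 cells (Homo sapiens) for inhibition, read by sulforhodamine B assay, with a stated time of 48 h (a higher number here means a weaker inhibitor of growth, a lower number a stronger inhibitor of growth), compound 1 reaches only the limit of the assay, > 50000 nM. Within the data shown here, it is the one compound of the three that stands at this limit (the limit of > 50000 nM in this assay, at which 1 of the 3 values shown sits). Compound 2 `COc1cc(-c2nn(-c3cccc(NC(=O)Nc4cccc(C(F)(F)F)c4)c3)cc2-c2ccncc2)ccc1Cl` differs from compound 1 in a single place, (3-(trifluoromethyl)phenyl)amino in place of 3-(trifluoromethyl)phenyl on the carbonyl carbon, and in this assay compound 2 gives 4070 nM, a step of an at least 12-fold lower number from compound 1 to compound 2 (1.08 log units; beyond the scatter). Compound 3 `O=C(Nc1cccc(-n2cc(-c3ccncc3)c(-c3ccc(Cl)c(O)c3)n2)c1)Nc1cc(C(F)(F)F)cc(C(F)(F)F)c1`, a second urea, gives 1980 nM in this assay.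

Compound 4 `COc1cc(-c2nn(-c3cccc(NC(=O)c4ccccc4)c3)cc2-c2ccncc2)ccc1Cl` keeps the amide of compound 1 and differs from it by hydrogen in place of trifluoromethyl on an aromatic carbon. Among the measured compounds shown here, no measured step removes a trifluoromethyl group, so none bears directly on this change; the only step measured from compound 1, an at least 12-fold lower number from compound 1 to compound 2 (1.08 log units; beyond the scatter), concerns the amide-to-urea change and leaves the trifluoromethyl ring untouched. With compound 1 standing at the limit (the limit of > 50000 nM in this assay, at which 1 of the 3 values shown sits), the step that the limit leaves unreadable from compound 1 to compound 4 is expected to show nothing beyond the scatter. Compound 4 is therefore estimated at 60000 nM, in the range 15000 nM to 250000 nM, most likely again reported only as a limit.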

Compound 4, concentration for total growth inhibition: > 100000 nM
Compound 4 was reported as a limit (the forecaster's own chance of this, stated with the estimate: 75%); middle value at least 1.6-fold (0.22 log units) away from the limit.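

In this assay compound 4 is reported only as a limit, > 100000 nM. Compound 1 is also a limit, so the effect of hydrogen in place of trifluoromethyl on the amide series cannot be read from this pair: the limit of > 50000 nM in this assay, at which 1 of the 4 values shown sits. Phenyl in place of (3-(trifluoromethyl)phenyl)amino on the carbonyl carbon gives an at least 24-fold higher number from compound 2 to compound 4 (1.39 log units; beyond the scatter), and among the compounds shown, the amides compound 1 and compound 4 both stand at limits, whereas the ureas compound 2 and compound 3 give numbers.

No pair of ureas shown differs only by the trifluoromethyl group, so what that group contributes on a urea remains open. Also open, as far as these compounds go, is how an amine or a carboxylic acid in place of the trifluoromethyl would read in either the amide or the urea.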